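A few compounds are considered here, and "the series" means these few. Any claim that something is new, unique, unknown or untested is made for them only; others in the source may bear on it.

Measured in a functional assay on HCT-116 cells (Homo sapiens) for inhibition, read by MTT assay, with a stated time of 48 h; a lower number here means a stronger inhibitor, a higher number a weaker inhibitor:
- compound 1 `O=C(CCCCOc1no[n+]([O-])c1S(=O)(=O)c1ccccc1)NO`: 2180 nM
- compound 2 `O=C(COCCOc1no[n+]([O-])c1S(=O)(=O)c1ccccc1)NO`: 13400 nM
- compound 3 `CC(C)(COc1no[n+]([O-])c1S(=O)(=O)c1ccccc1)C(=O)NO`: 9740 nM

Compound 3 stands in the upper part of this small range. The step of a 1.4-fold lower number from compound 2 to compound 3 (0.14 log units; within the scatter) does not separate it from its nearest neighbour, while the clear gap is a 4.5-fold higher number from compound 1 to compound 3 (0.65 log units; beyond the scatter). The other step beyond the scatter is a 6.1-fold higher number from compound 1 to compound 2 (0.79 log units; beyond the scatter).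

The next compound is compound 4 `O=C(/C=C/COc1no[n+]([O-])c1S(=O)(=O)c1ccccc1)NO`, and the change is 2-(hydroxycarbamoyl)ethenyl in place of 1-(hydroxycarbamoyl)-1-methylethyl on a saturated chain carbon bound to an oxygen on an aromatic ring. Within the data shown here, no measured step brings in 2-(hydroxycarbamoyl)ethenyl, so the evidence is indirect. The closest guide is the same leaving group exchanged for 3-(hydroxycarbamoyl)propyl, which is the step of a 4.5-fold higher number from compound 1 to compound 3 (0.65 log units; beyond the scatter) read in reverse. Compound 2 goes against any general gain from leaving that group: with ((hydroxycarbamoyl)methoxy)methyl in its place, compound 2 gives 13400 nM.

The entering group resembles the 3-(hydroxycarbamoyl)propyl of compound 1 more than the group in compound 2, but it is shorter and carries a double bond. Only part of the gap to compound 1 is therefore expected to be recovered, which points to a small move toward a lower number in this assay. The expected step is a 1.9-fold lower number from compound 3 to compound 4 (0.29 log units; within the scatter). For compound 4 the estimated value is 5000 nM, with an expected range of 1900 nM to 13000 nM.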

Compound 4, half-maximal inhibitory concentration: 59900 nM
The estimate for compound 4 lay 12-fold (1.08 log units) below the measured number; measured number outside the range, above it.
By their numbers in this assay, from the lowest: compound 1; then compounds 3 and 2 (each within the scatter of the next); then compound 4.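

In this assay, 2-(hydroxycarbamoyl)ethenyl on a saturated chain carbon bound to an oxygen on an aromatic ring makes compound 4 the weakest inhibitor of the four, with every step to it beyond the scatter (a 6.1-fold higher number from compound 3 to compound 4 (0.79 log units; beyond the scatter); a 4.5-fold higher number from compound 2 to compound 4 (0.65 log units; beyond the scatter); a 27-fold higher number from compound 1 to compound 4 (1.44 log units; beyond the scatter)). Among these compounds, until now, the changes from compound 1 had led only to compound 2 and compound 3, which lie within the scatter of each other, so the earlier compounds suggested a shallower penalty at this position than compound 4 reveals, and 2-(hydroxycarbamoyl)ethenyl does not retain the number of the 3-(hydroxycarbamoyl)propyl group of compound 1 despite the resemblance between the two chains. Nothing available explains this rise in the number at this position.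

The compounds shown cannot separate the effect of the double bond from that of chain length, as no saturated group and unsaturated group of the same length are compared here. Also open, going by these compounds, is how a longer chain carrying the same double bond would read in this assay, and whether a carboxylic acid in place of the hydroxycarbamoyl group would keep any of the activity seen at this position.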